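The source may report more compounds than this note shows. Statements on the series, on what has been measured and on what is new or still open speak of the compounds shown alone.

Values in a functional assay on MCF7 cells (Homo sapiens) for antiproliferative activity (a higher number here means a weaker inhibitor, a lower number a stronger inhibitor), are these:
Compound 1 `C#CCOc1ccc(C(=O)Nc2cc3ccc(OC4CCN(C)CC4)c(C)c3oc2=O)cc1CC=C(C)C`: 1120 nM
Compound 2 `Cc1c(OC2CCN(C)CC2)ccc2cc(NC(=O)c3ccc(O)c(CCC(C)C)c3)c(=O)oc12`: 1250 nM
Compound 3 `Cc1c(OC2CCN(C)CC2)ccc2cc(NC(=O)c3ccccc3)c(=O)oc12`: 11700 nM

Compound 2 lies within the scatter of compound 1, while compound 3 has a number beyond the scatter above compound 2. Compound 4 `COc1cccc(-c2cc(C(=O)Nc3cc4ccc(OC5CCN(C)CC5)c(C)c4oc3=O)ccc2O)c1` is compound 2 with 3-methoxyphenyl in place of isopentyl on an aromatic carbon, ortho to a hydroxy group (3-methoxyphenyl in place of isopentyl on an aromatic carbon). Going by the values given here, no measured pair shows this change. Compound 1 at 1120 nM and compound 2 at 1250 nM agree within the scatter although their groups differ, so no step beyond the scatter is expected in this assay for this replacement, with a lean toward a stronger inhibitor. The expected step (a 1.8-fold lower number from compound 2 to compound 4 (0.25 log units; within the scatter)) is therefore small. Compound 4 is estimated at 700 nM with an expected range from 200 nM to 2500 nM at its two ends.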

Compound 4, half-maximal inhibitory concentration: 810 nM
For compound 4 the middle estimate is 1.2-fold (0.06 log units) below the measured one; the measured number falls inside the stated range.
By their numbers in this assay, from the lowest: compounds 4, 1 and 2 (each within the scatter of the next); then compound 3.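

In this assay, going by these compounds alone, the place ortho to a hydroxy group accepts a six-membered aromatic ring as readily as an open chain: 3-methoxyphenyl in place of isopentyl gives a 1.5-fold lower number from compound 2 to compound 4 (0.19 log units; within the scatter), so the larger group, with its added hydrogen-bond acceptor, brings no step that can be told from the scatter. Nothing measured here gives a reason for this result.

Going by these compounds, whether an amine or a carboxylic acid at this place would behave the same remains open. So does the part played by the methoxy group on the new ring, since an unsubstituted phenyl is not among these compounds.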